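Swapping the amide's furan for an anilino group

The compounds below may be only part of what the source reports. "The series", "measured", "known", "first", "only" and "open" are said of these compounds alone.

Of the compounds shown here, three with a shared core have been measured in an assay on cells for displacement of a labelled ligand from adenosine receptor A1 (Homo sapiens), read by scintillation counting, with a stated time of 120 min, tested at 1 uM; a higher number here means more inhibition at the concentration tested (going by the name of the read-out), a lower number less inhibition. Compound 1 `O=C(Nc1nccn2cc(-c3ccccc3)nc12)c1ccccc1` gives 18%. Compound 2 `COc1ccc(C(=O)Nc2nccn3cc(-c4ccccc4)nc23)cc1` gives 1%, and the change from compound 1 to compound 2 is a number 17 percentage points lower from compound 1 to compound 2 (beyond the scatter). Compound 3 `O=C(Nc1nccn2cc(-c3ccccc3)nc12)c1ccco1` gives 25%, the highest of the three numbers, though the step of a number 7 percentage points higher from compound 1 to compound 3 (within the scatter) is within the scatter, while the step of a number 24 percentage points higher from compound 2 to compound 3 (beyond the scatter) is beyond it.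

Compound 4 `O=C(Nc1ccccc1)Nc1nccn2cc(-c3ccccc3)nc12` has not been measured. It differs from compound 3 as follows: anilino in place of furan-2-yl on a carbonyl carbon. Going by the values given here, the two measured steps that alter the group on the carbonyl carbon, a number 7 percentage points higher from compound 1 to compound 3 (within the scatter) and a number 24 percentage points higher from compound 2 to compound 3 (beyond the scatter), were small to modest, and none of the measured compounds carries an anilino group there, so the comparison is only partial. A change of modest size at most is therefore expected, in either direction, most likely a slight drop.

Compound 4 is estimated at 15%, within 0% to 35%. This estimate means an expected step of a number 10 percentage points lower from compound 3 to compound 4 (within the scatter).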

Compound 4, a percentage reported as inhibition, at one concentration (the size of the read-out at that concentration, not a potency): 1%
Beside the measured number, compound 4's estimate is 14 percentage points above it; low and high end bracket the measured number.
By their numbers in this assay, from the lowest: compounds 2 and 4 (each within the scatter of the next); then compounds 1 and 3 (each within the scatter of the next).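

Of the groups shown on this carbonyl carbon, anilino is the only one that attaches through a nitrogen and counts a hydrogen-bond donor, and in this assay it gives a number 24 percentage points lower from compound 3 to compound 4 (beyond the scatter) and also a number 17 percentage points lower from compound 1 to compound 4 (beyond the scatter) in place of phenyl. The furan-2-yl and phenyl compounds therefore stand apart from compound 4, while the step to anilino from 4-methoxyphenyl is no change at the digits printed from compound 2 to compound 4 (within the scatter) and places these two different groups together at the low end of the series. Nothing measured here explains why anilino gives this low reading.

From the compounds shown here alone, whether the linking nitrogen or the ring it carries matters more stays open. A benzylamino group or a plain methylamino group at this place would help separate the two, and a pyrrolidine ring attached through its nitrogen would show what happens without the hydrogen on that nitrogen.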